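The source may report more compounds than this note shows. Statements on the series, on what has been measured and on what is new or still open speak of the compounds shown alone.

Within the data shown here, in a functional assay on U-373MG ATCC cells (Homo sapiens) for cytotoxicity, read by MTT assay, with a stated time of 72 h (a lower number here means a stronger inhibitor, a higher number a weaker inhibitor), compound 2 `COc1ccc2[nH]c(-c3ccc[nH]3)cc2c1` gives 43000 nM, the only true number so far. Compound 1 `c1ccc2[nH]c(-n3cccn3)cc2c1`, which also carries 1H-pyrazol-1-yl, gives > 100000 nM, a limit of the assay and not a number. Compound 3 `COc1ccc2[nH]c(-n3cccn3)cc2c1` places 1H-pyrazol-1-yl in place of 1H-pyrrol-2-yl on an aromatic carbon, next to the ring nitrogen (1H-pyrazol-1-yl in place of 1H-pyrrol-2-yl on an aromatic carbon). No measured step sizes this change in this assay. The expected 1.4-fold higher number from compound 2 to compound 3 (0.14 log units; within the scatter) is a small weakening, perhaps no larger than the scatter. For compound 3 the estimate is 60000 nM, with an expected range of 25000 nM to 120000 nM.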

Compound 3, half-maximal inhibitory concentration: > 100000 nM
Compound 3: a limit, no number; the forecaster's own chance of this, stated with the estimate: 35%; middle value at least 1.6-fold (0.22 log units) away from the limit.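

In this assay compound 3 gives > 100000 nM, a limit of the assay and not a number. Among these compounds, on the aromatic carbon next to the ring nitrogen, 1H-pyrazol-1-yl in place of 1H-pyrrol-2-yl gives an at least 2.3-fold higher number from compound 2 to compound 3 (0.36 log units; beyond the scatter), the first sized step. The methoxy step between the two limit compounds cannot be read, and the pyrazolyl step gives only a lower bound: the limit of > 100000 nM in this assay, at which 2 of the 3 values shown sit.

Still open, going by these compounds, is how far the number moves with a 1H-pyrrol-2-yl replacement other than 1H-pyrazol-1-yl, such as an amine or a carboxylic acid at that carbon. Also open, on these data alone, is the effect of a longer chain in place of methoxy.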